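PLK1 urea series: methoxyphenyl swap on the fluoro core

A few compounds are considered here, and "the series" means these few. Any claim that something is new, unique, unknown or untested is made for them only; others in the source may bear on it.

Measured so far, all in an assay on isolated protein for inhibition of serine/threonine-protein kinase PLK1 (Homo sapiens), read by radiometric assay and 33P incorporation, with a stated time of 40 min, tested at 20 uM, in the presence of a further agent that is not named here; on this read-out higher numbers stand for more inhibition at the one concentration tested (going by the name of the read-out) and lower numbers for less inhibition:
compound 1 `CCNc1cc(-c2ccc(NC(=O)Nc3cccc(Cl)c3)cc2C(F)(F)F)ccn1`: compound 1 gives 94.9%
compound 2 `CCNc1cc(-c2ccc(NC(=O)Nc3ccc(OC)cc3)cc2C(F)(F)F)ccn1`: compound 2 gives 62.1%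
compound 3 `CCNc1cc(-c2ccc(NC(=O)Nc3cccc(Cl)c3)cc2F)ccn1`: compound 3 gives 72.7%

Two single changes branch from compound 1. One is 4-methoxyphenyl in place of 3-chlorophenyl on an amide-type nitrogen, and it gave a number 32.8 percentage points lower from compound 1 to compound 2 (beyond the scatter). The other is fluoro in place of trifluoromethyl on an aromatic carbon, and it gave a number 22.2 percentage points lower from compound 1 to compound 3 (beyond the scatter). Compound 3 sits between the other two on this read-out.

Compound 4 `CCNc1cc(-c2ccc(NC(=O)Nc3ccc(OC)cc3)cc2F)ccn1` is not yet measured. It differs from compound 3 by 4-methoxyphenyl in place of 3-chlorophenyl on an amide-type nitrogen, which is the same change as that from compound 1 to compound 2, at the same place. The two cores differ by fluoro in place of trifluoromethyl on an aromatic carbon. Taking the step from compound 1 to compound 2 as the guide, a drop of similar size from compound 3 is expected, a number 32.7 percentage points lower from compound 3 to compound 4 (beyond the scatter), because compound 3 starts from 72.7%. Compound 4 is therefore estimated at 40%, between 22% and 58%.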

Compound 4, a percentage reported as inhibition, at one concentration (the size of the read-out at that concentration, not a potency): 47.1%
Beside the measured number, compound 4's estimate is 7.1 percentage points below it; the measured number falls inside the stated range.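

In this assay, 4-methoxyphenyl in place of 3-chlorophenyl on the core of compound 3 goes with a number 25.6 percentage points lower from compound 3 to compound 4 (beyond the scatter), and this change carries over from the core of compound 1 at a similar size: the same change on two cores in this assay, a number 32.8 percentage points lower (beyond the scatter) from compound 1 to compound 2 and a number 25.6 percentage points lower (beyond the scatter) from compound 3 to compound 4, 7.2 percentage points apart, within the scatter of two such steps. Read the other way, fluoro in place of trifluoromethyl goes with a number 15 percentage points lower from compound 2 to compound 4 (beyond the scatter), and this change also carries over between the two aryl ureas: the same change on two cores in this assay, a number 22.2 percentage points lower (beyond the scatter) from compound 1 to compound 3 and a number 15 percentage points lower (beyond the scatter) from compound 2 to compound 4, 7.2 percentage points apart, within the scatter of two such steps. These four compounds show the two changes combining about additively at the one concentration tested, but they do not show this for any other core or give a potency.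

The compounds shown leave open whether the drop follows the gain of methoxy or the loss of chlorine, as the two change together. Also open, as far as these compounds go, is how a nitrile or a methyl group on that aromatic carbon would behave.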